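The source may hold more compounds than are shown below. What is called first, only, known or untested is meant among the compounds shown, and "the series" means these compounds.

Compound 1, `CN(C)/N=N/c1ccc(C(N)=O)cc1`, gives 3.51 in a functional assay on L1210 cells (Mus musculus) for antiproliferative activity; a lower number here means a less potent compound, a higher number a more potent compound, by a factor of ten per unit of this negative logarithm. Compound 2, `CCCN(C)/N=N/c1nc[nH]c1C(N)=O`, gives 3.58 in this assay. Compound 3, `CCN(C)/N=N/c1ccc(C(N)=O)cc1`, gives 3.66 in this assay.

Compound 3 differs from compound 1 by a single change, (methyl in place of hydrogen on a saturated chain carbon bound to an amine nitrogen), and this step moved the read-out by a number 0.15 log units higher from compound 1 to compound 3 (within the scatter). Compound 4, `CC(C)CN(C)/N=N/c1nc[nH]c1C(N)=O`, is not yet measured; it differs from compound 2 by methyl in place of hydrogen on a saturated chain carbon bound to two saturated chain carbons. The difference between the cores of compound 1 and compound 2 is not broken down here. The two changes are the same kind of change, but the place differs: in compound 3 the new methyl sits on a saturated chain carbon bound to an amine nitrogen, whereas in compound 4 it sits on a saturated chain carbon bound to two saturated chain carbons. Resting on the step of a number 0.15 log units higher from compound 1 to compound 3 (within the scatter) from compound 1, the step from compound 2 to compound 4 is expected to be about a number 0.12 log units higher from compound 2 to compound 4 (within the scatter). Compound 4 is therefore estimated at 3.7, between 3.3 and 4.1.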

Compound 4, logarithm of the reciprocal of the active concentration, log(1/C): 3.51
For compound 4 the middle estimate is 0.19 log units above the measured one, within the range that was stated.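

In this assay, the step from propyl to isobutyl reads a number 0.07 log units lower from compound 2 to compound 4 (within the scatter), so adding this methyl has no effect that can be told from the scatter on this core. Set beside the earlier step, the same kind of change gives results on the two cores that cannot be told apart: the same change on two cores in this assay, a number 0.15 log units higher (within the scatter) from compound 1 to compound 3 and a number 0.07 log units lower (within the scatter) from compound 2 to compound 4, 0.22 log units apart, within the scatter of two such steps. This gives no sign that the core matters, but it does not prove that the step carries over, as both steps are small and the new methyl sits on a different kind of carbon in each case.

The compounds shown leave open whether a larger change would give a clear step on either core. A longer chain or a carboxylic acid in place of the propyl of compound 2 would be one such case.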